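Swapping Methyl for Phenyl on a Ring Nitrogen

The source may hold more compounds than are shown below. What is called first, only, known or untested is meant among the compounds shown, and "the series" means these compounds.

Measured so far in a functional assay on A549 cells (Homo sapiens) for inhibition, read by colorimetric assay and MTT assay, with a stated time of 72 h; a lower number here means a stronger inhibitor, a higher number a weaker inhibitor:
- Compound 1 `C/C1=C\CC[C@@]2(C)O[C@@H]2[C@H]2OC(=O)[C@@H](CN3CCCC3)[C@@H]2C[C@H]1O` gives 10000 nM
- Compound 2 `C/C1=C\CC[C@@]2(C)O[C@@H]2[C@H]2OC(=O)[C@@H](CN3CCN(C)CC3)[C@@H]2C[C@H]1O` gives 30000 nM
- Compound 3 `C/C1=C\CC[C@@]2(C)O[C@@H]2[C@H]2OC(=O)[C@@H](CN(C)CCN(C)C)[C@@H]2C[C@H]1O` gives 8000 nM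

These three compounds share one core and differ only in the amine group on a saturated chain carbon. Compound 2 has the highest number of the three, which makes it the weakest inhibitor in this small set.

The untested compound 4 `C/C1=C\CC[C@@]2(C)O[C@@H]2[C@H]2OC(=O)[C@@H](CN3CCN(c4ccccc4)CC3)[C@@H]2C[C@H]1O` keeps the ring of compound 2 but has phenyl in place of methyl on an amine nitrogen in a ring. Within the data shown here, no measured pair makes this exact change. The closest evidence comes from swaps of the whole amine group, which gave a 3.0-fold higher number from compound 1 to compound 2 (0.48 log units; beyond the scatter) and a 3.8-fold lower number from compound 2 to compound 3 (0.57 log units; beyond the scatter). Both are modest steps, so a step of about that size or smaller is expected in this assay. On these data alone, compound 2 already sits at the top of the range at 30000 nM, so a lower number seems somewhat more likely, though phenyl itself is untested here. The expected step is a 2.0-fold lower number from compound 2 to compound 4 (0.30 log units; within the scatter). The estimate for compound 4 is 15000 nM, with an expected range from 6000 nM to 40000 nM.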

Compound 4, half-maximal inhibitory concentration: 17000 nM
Estimate against measurement, compound 4: 1.1-fold (0.05 log units) below, and the stated range covers the measured number.
By their numbers in this assay, from the lowest: compounds 3, 1, 4 and 2 (each within the scatter of the next, the first and the last beyond it).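

In this assay the change of phenyl in place of methyl on an amine nitrogen in a ring gives a 1.8-fold lower number from compound 2 to compound 4 (0.25 log units; within the scatter) and so leaves the two compounds indistinguishable. The earlier steps shown here replaced the whole amine group, whereas this one keeps the six-membered ring with its 2 nitrogen and alters only the group on the amine nitrogen, three ring bonds from the ring atom that bears a large group. At this position, a single carbon can give way to six heavy atoms and a six-membered aromatic ring without a step beyond the scatter, although no data here explain that outcome.

A single swap cannot show how far this holds, so open questions remain about a plain hydrogen, an ethyl, a benzyl or an acetyl group on the same nitrogen. A phenyl ring carrying a fluorine or a methoxy group could also be informative, as it would show whether changes on the new ring itself move the number beyond the scatter.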